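Adding a Methyl Group to an Orexin Receptor Agonist

The source may hold more compounds than are shown below. What is called first, only, known or untested is meant among the compounds shown, and "the series" means these compounds.

Compound 1 `COc1ccccc1C(=O)N(C)c1cccc2ccc(NS(=O)(=O)c3cc(-c4cccc(C(=O)N(C)C)c4)ccc3OC)cc12` was tested in a functional assay on CHO cells for agonist activity at Orexin/Hypocretin receptor type 1 (Homo sapiens); on this read-out lower numbers stand for an effect already at smaller amounts and higher numbers for an effect only at larger amounts of compound. In this assay compound 1 gives only the limit > 10000 nM, not a number. Compound 2 `COc1cccc(C(=O)N(C)c2cccc3ccc(NS(=O)(=O)c4cc(-c5cccc(C(=O)N(C)C)c5)ccc4OC)cc23)c1` differs from it by a 3-methoxyphenyl in place of a 2-methoxyphenyl on a carbonyl carbon, and in this assay compound 2 gives 232 nM. The step of an at least 43-fold lower number from compound 1 to compound 2 (1.63 log units; beyond the scatter) is the only measured one, and it is beyond the scatter. Among the values shown, compound 2 thus holds the only real number.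

Compound 3 `COc1cccc(C(=O)N(C)c2c(C)ccc3ccc(NS(=O)(=O)c4cc(-c5cccc(C(=O)N(C)C)c5)ccc4OC)cc23)c1` has not yet been measured. It differs from compound 2 by methyl in place of hydrogen on an aromatic carbon. For the measured compounds named here, no measured step touches this ring of the shared core; the single step measured, from compound 1 to compound 2, concerns the position of a methoxy group on a different ring. With nothing directly comparable, the step from compound 2 to compound 3 is expected to stay within the usual scatter, as a 1.3-fold higher number from compound 2 to compound 3 (0.11 log units; within the scatter). Compound 3 is therefore estimated to give 300 nM in this assay, with a range from 80 nM to 1500 nM.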

Compound 3, half-maximal effective concentration: 260 nM
Compound 3: middle estimate off by 1.2-fold (0.06 log units), on the high side; measured number inside the range.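

In this assay the methyl on the aromatic carbon ortho to the ((3-methoxyphenyl)carbonyl)(methyl)amino group gives a 1.1-fold higher number from compound 2 to compound 3 (0.05 log units; within the scatter) and so the two compounds cannot be told apart on this read-out. For the compounds shown here, this is the first information about this ring of the shared core: here, a methyl can take the place of hydrogen and the agonist effect remains measurable, whereas the only earlier step of an at least 43-fold lower number from compound 1 to compound 2 (1.63 log units; beyond the scatter) came from a methoxy group at a different place on a different ring. Nothing shown here explains why the methyl leaves the read-out within the usual scatter.

Going by these compounds, what remains open is whether this carbon would accept a longer chain such as ethyl, or a group of another kind such as an amine or a carboxylic acid, as well as it accepts methyl. On these data alone, it is also open whether a methyl on another carbon of this ring would read the same, or whether this one would do so alongside the 2-methoxyphenyl group of compound 1.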